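The source may hold more compounds than are shown below. What is called first, only, known or untested is meant among the compounds shown, and "the series" means these compounds.

Among the compounds with values here, compound 1 `O=S(=O)(Nc1ccc(-c2nc3ccccc3o2)cc1)c1cccc(F)c1` is one of two compounds measured in an assay on cells for inhibition of HSP60/HSP10 (Homo sapiens), with a stated time of 60 min; on this read-out lower numbers stand for stronger inhibition and higher numbers for weaker inhibition. In this assay compound 1 gives 71000 nM, the higher of the two numbers recorded; compound 2 `O=S(=O)(Nc1ccc(-c2nc3ccccc3o2)cc1)c1ccc(F)c(C(F)(F)F)c1` gives 28000 nM, a lower number lying beyond the usual scatter, so compound 1 stands as the weaker of the pair.

Compound 3 `COc1cccc(S(=O)(=O)Nc2ccc(-c3nc4ccccc4o3)cc2)c1` has not yet been measured in this assay. Its structure departs from compound 1 at a single point: methoxy in place of fluoro on an aromatic carbon. Within the data shown here, no pair of measured compounds shows this change, so its effect on the numbers is unknown. Since compound 1 already sits high on the scale and the change is small, the step is expected to be modest, in either direction, and may not exceed the scatter. Compound 3 is therefore expected to give about 60000 nM in this assay, within a range of 25000 nM to 150000 nM. The step expected from this change is a 1.2-fold lower number from compound 1 to compound 3 (0.07 log units; within the scatter).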

Compound 3, half-maximal inhibitory concentration: 80000 nM
Compound 3: the middle estimate sits 1.3-fold (0.12 log units) below what was measured, within the range that was stated.
By their numbers in this assay, from the lowest: compound 2; then compounds 1 and 3 (each within the scatter of the next).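

In this assay putting methoxy in place of fluoro on this aromatic carbon, meta to a large group, gives a 1.1-fold higher number from compound 1 to compound 3 (0.05 log units; within the scatter) and so leaves the 3-fluorophenyl and 3-methoxyphenyl compounds indistinguishable on this read-out. Within the data shown here, this is the first comparison here of compounds that differ in one place, and it shows that a group of two heavy atoms with a hydrogen-bond acceptor can stand at this position in place of a single fluorine without a difference the assay can resolve. No available evidence bears on why these two groups read alike.

On these data alone, whether an amine, a carboxylic acid or a longer chain such as butoxy at this position would give a number beyond the scatter remains open. So does how the unsubstituted phenyl ring would read against the 3-fluorophenyl and 3-methoxyphenyl compounds.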